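Piperazine aryl change in the aminothiophene series: difluoro pattern

This account rests on a few compounds, and the source may have more. Where it says the series, first, only, none or still open, it means among the compounds named here.

Compound 3 `Nc1scc(CN2CCN(c3ccc(F)c(F)c3)CC2)c1C(=O)c1ccc(Cl)cc1` gives -34% in a functional assay on CHO cells with adenosine receptor A1 (Homo sapiens) as the target, read by cAMP accumulation and immunoassay, with a stated time of 6 min, tested at 0.1 uM (on this read-out lower numbers stand for a stronger effect and higher numbers for a weaker effect at the one concentration tested), the lowest of the three numbers and therefore the strongest effect at this concentration. Compound 1 `Nc1scc(CN2CCN(c3ccc(Cl)cc3F)CC2)c1C(=O)c1ccc(Cl)cc1` gives -9.4% and compound 2 `Nc1scc(CN2CCN(c3ccc(OC(F)(F)F)cc3)CC2)c1C(=O)c1ccc(Cl)cc1` gives -13%. The steps of a number 24.6 percentage points lower from compound 1 to compound 3 (beyond the scatter) and a number 21 percentage points lower from compound 2 to compound 3 (beyond the scatter) both bear on the aryl group on the ring nitrogen, whereas a number 3.6 percentage points lower from compound 1 to compound 2 (within the scatter) does not move the number. Within the data shown here, compound 4 `Nc1scc(CN2CCN(c3cc(F)cc(F)c3)CC2)c1C(=O)c1ccc(Cl)cc1` carries the change (3,5-difluorophenyl in place of 3,4-difluorophenyl on an amine nitrogen in a ring); no measured step moves a fluorine within the ring, so the direction is not fixed by the data. The expectation is a modest rise, a number 14 percentage points higher from compound 3 to compound 4 (beyond the scatter), toward the other two aryl groups, since only compound 3 shows the lower value -34%. Compound 4 is estimated at -20%, within -42% to 2%.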

Compound 4, a percentage reported as activity, at one concentration (the size of the read-out at that concentration, not a potency): -5%
Beside the measured number, compound 4's estimate is 15 percentage points below it; low and high end bracket the measured number.
By their numbers in this assay, from the lowest: compound 3; then compounds 2, 1 and 4 (each within the scatter of the next).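

Fluorine placement alone matters at this position: with the same atoms joined differently, this assay shows a number 29 percentage points higher from compound 3 to compound 4 (beyond the scatter) and so two fluorines as such do not carry the low number. Compound 4 falls in with the other aryl groups, with a number 8 percentage points higher from compound 2 to compound 4 (within the scatter) and a number 4.4 percentage points higher from compound 1 to compound 4 (within the scatter) and the 3,4-difluorophenyl of compound 3 alone stands apart among the four.

As far as these compounds go, whether 3,4-dichlorophenyl or 4-fluorophenyl on the ring nitrogen would keep the low number stays open. Nothing available explains the difference between the two difluoro patterns.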